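This account rests on a few compounds, and the source may have more. Where it says the series, first, only, none or still open, it means among the compounds named here.

Measured compounds:
- compound 1 `COc1nc(C2CCOCC2)ccc1[C@@H](c1ccccc1)[C@@](O)(CCN(C)C)c1cccc2ccccc12`: in a toxicity assay on HeLa cells (Homo sapiens) for cytotoxicity (a higher number here means that more compound is tolerated, a lower number that less compound is tolerated), compound 1 gives 22.5 ug/mL.
- compound 2 `COc1ccc(-c2ccc([C@@H](c3ccccc3)[C@@](O)(CCN(C)C)c3cccc4ccccc34)c(OC)n2)cc1`: in this assay compound 2 reaches only the limit > 64 ug/mL, which is a limit of the assay and not a number.

Among the measured compounds shown here, compound 1 holds the only actual number in this assay; the other entry is a limit. Compound 2 differs from compound 1 by 4-methoxyphenyl in place of oxan-4-yl on an aromatic carbon, and that step is an at least 2.8-fold higher number from compound 1 to compound 2 (0.45 log units; beyond the scatter), which rests on (the limit of > 64 ug/mL in this assay, at which 1 of the 2 values shown sits).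

Compound 3 `COc1nc(-c2ccccc2Cl)ccc1[C@@H](c1ccccc1)[C@@](O)(CCN(C)C)c1cccc2ccccc12` is not yet measured in this assay. It differs from compound 1 thus: 2-chlorophenyl in place of oxan-4-yl on an aromatic carbon. For the measured compounds named here, the one measured step that bears on it is the change from compound 1 to compound 2, where an aromatic ring replaced oxan-4-yl on an aromatic carbon and the number rose beyond the scatter, at least to the limit. A 2-chlorophenyl is a different aromatic ring, so the size is uncertain, yet a rise in the same direction is expected.

For compound 3 the step is estimated at a 2.2-fold higher number from compound 1 to compound 3 (0.35 log units; beyond the scatter), and the value is expected near 50 ug/mL, in the range 22 ug/mL to 110 ug/mL.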

Compound 3, half-maximal cytotoxic concentration: > 64 ug/mL
Compound 3: only a limit was reported; the forecaster's own chance of this, stated with the estimate: 40%; at least 1.2-fold (0.10 log units) between middle value and limit.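

In this assay, 2-chlorophenyl in place of oxan-4-yl on the aromatic carbon next to the ring nitrogen gives an at least 2.8-fold higher number from compound 1 to compound 3 (0.45 log units; beyond the scatter). For compound 3, > 64 ug/mL is a limit of the assay and not a number. The rise at this position therefore no longer rests on 4-methoxyphenyl alone, since two differently substituted six-membered aromatic rings now move the number the same way from oxan-4-yl, while the step between compound 2 and compound 3 cannot be read and the two aromatic groups cannot be ordered: the limit of > 64 ug/mL in this assay, at which 2 of the 3 values shown sit.

Among the compounds shown here, whether the rise requires an aromatic ring at this position stays open, as oxan-4-yl is the only non-aromatic group here, and an open-chain amine or a carboxylic acid in its place would probe that question. Going by these compounds, how much compound is tolerated beyond the limit shared by compound 2 and compound 3 also stays open, so any real difference between 4-methoxyphenyl and 2-chlorophenyl remains hidden in this assay.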